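The source may report more compounds than this note shows. Statements on the series, on what has been measured and on what is new or still open speak of the compounds shown alone.

Measured in a functional assay on HeLa cells (Homo sapiens) for inhibition, read by sulforhodamine B assay; on this read-out higher numbers stand for weaker inhibition and lower numbers for stronger inhibition:
Compound 1 `COc1cccc(NC2=CC(=O)c3nc4n(c3C2=O)[C@H]2OC[C@@H](O)[C@H]2OC4)c1` gives 4280 nM.
Compound 2 `O=C1C(NC2CCCC2)=CC(=O)c2c1nc1n2[C@H]2OC[C@@H](O)[C@H]2OC1` gives only a limit of the assay, > 16000 nM.
Compound 3 `O=C1C(N2CCCC2)=CC(=O)c2c1nc1n2[C@H]2OC[C@@H](O)[C@H]2OC1` gives only a limit of the assay, > 16000 nM.

Among the compounds with values here, compound 1 stands as the only compound with a number in this assay; the other two values sit at the limit of > 16000 nM in this assay, at which 2 of the 3 values shown sit. Within the data shown here, the sole one-place step, a step that the two limits leave unreadable from compound 2 to compound 3, cannot be read because both ends are limits. Compound 4 `CCCc1ccc(NC2=CC(=O)c3nc4n(c3C2=O)[C@H]2OC[C@@H](O)[C@H]2OC4)cc1` differs from compound 1 by 4-propylphenyl in place of 3-methoxyphenyl on an amine nitrogen. No readable measured step exists in this series, so nothing sets a size or a direction for this change. The expectation is therefore a step within the scatter, a 1.1-fold higher number from compound 1 to compound 4 (0.02 log units; within the scatter), held with wide uncertainty. Compound 4 is estimated at 4500 nM in this assay, within 1200 nM to 16000 nM.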

Compound 4, half-maximal inhibitory concentration: 4990 nM
Beside the measured number, compound 4's estimate is 1.1-fold (0.04 log units) below it; low and high end bracket the measured number.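

In this assay, within the data shown here, putting 4-propylphenyl in place of 3-methoxyphenyl on the amine nitrogen gives a 1.2-fold higher number from compound 1 to compound 4 (0.07 log units; within the scatter), the first readable step. At this position, the group can therefore lose its hydrogen-bond acceptor with no change beyond the scatter. Compound 2 and compound 3 remain limits of the assay: the limit of > 16000 nM in this assay, at which 2 of the 4 values shown sit.

The substituent and its place on the phenyl ring change together here, so neither can be read alone. From the compounds shown here alone, whether an unsubstituted phenyl, or a phenyl carrying a carboxylic acid or an amine, would move the number stays open.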